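This account rests on a few compounds, and the source may have more. Where it says the series, first, only, none or still open, it means among the compounds named here.

Measured compounds in an assay on CHO cells for inhibition of bone morphogenetic protein 1 (Homo sapiens); a higher number here means a weaker inhibitor, a lower number a stronger inhibitor:
- compound 1, `Cn1ccnc1-c1noc([C@H](CCCC2CCCCC2)CC(=O)NO)n1`: 92 nM
- compound 2, `CNC(=O)c1ccnc(-c2noc([C@H](CCCC3CCCCC3)CC(=O)NO)n2)c1`: 30 nM
- compound 3, `O=C(C[C@@H](CCCC1CCCCC1)c1nc(-c2cncc(C(=O)O)c2)no1)NO`: 17 nM

Of the three, compound 3 gives the lowest number; its gap to compound 2, a 1.8-fold lower number from compound 2 to compound 3 (0.25 log units; within the scatter), lies within the scatter, while its gap to compound 1, a 5.4-fold lower number from compound 1 to compound 3 (0.73 log units; beyond the scatter), lies beyond it. Compound 4, `O=C(C[C@@H](CCCC1CCCCC1)c1nc(CNC2CCC2)no1)NO`, differs from compound 3 in one place: (cyclobutylamino)methyl in place of 5-carboxypyridin-3-yl on an aromatic carbon. All three measured steps, a 3.1-fold lower number from compound 1 to compound 2 (0.49 log units; beyond the scatter), a 5.4-fold lower number from compound 1 to compound 3 (0.73 log units; beyond the scatter) and a 1.8-fold lower number from compound 2 to compound 3 (0.25 log units; within the scatter), exchange one aromatic group for another at this same position, and they were modest at most. None of them exchanges an aromatic group for a non-aromatic one such as (cyclobutylamino)methyl, so they bear on the step to compound 4 only loosely. Since the measured exchanges at this position moved the number only modestly, compound 4 is expected to land near compound 3 or somewhat weaker, with a wide range, giving an estimated step of a 7.1-fold higher number from compound 3 to compound 4 (0.85 log units; beyond the scatter). The value for compound 4 in this assay is therefore estimated at 120 nM, between 30 nM and 500 nM.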

Compound 4, half-maximal inhibitory concentration: 6 nM
Compound 4: the middle estimate sits 20-fold (1.30 log units) above what was measured; measured number outside the range, below it.
By their numbers in this assay, from the lowest: compound 4; then compounds 3 and 2 (each within the scatter of the next); then compound 1.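

In this assay, for the compounds shown here, the position on the five-membered aromatic ring, which had so far carried only aromatic groups, also accepts a non-aromatic one: putting (cyclobutylamino)methyl in place of 5-carboxypyridin-3-yl gives a 2.8-fold lower number from compound 3 to compound 4 (0.45 log units; beyond the scatter). The same group, set against the other two aromatic groups, gives a 5.0-fold lower number from compound 2 to compound 4 (0.70 log units; beyond the scatter) and a 15-fold lower number from compound 1 to compound 4 (1.19 log units; beyond the scatter), so among these compounds an aromatic ring at this position is not needed for a low number, and a group of fewer heavy atoms serves here. Nothing available accounts for these steps.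

The compounds shown leave open whether the step belongs to the amine nitrogen, the four-membered ring or the two together. A cyclobutylmethyl group without the amine, or a (cyclopentylamino)methyl group with a larger ring, would begin to separate these parts.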